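From 3,4-difluorophenyl to 4-methoxyphenyl on an amide nitrogen

The source may hold more compounds than are shown below. What is called first, only, known or untested is meant among the compounds shown, and "the series" means these compounds.

Compound 1 `COc1cc(NC(=O)/C=C/c2cccc(OCc3ccccc3)c2)cc(OC)c1OC` gives 2400 nM
Compound 2 `C=C(Br)C(=O)Nc1cccc(/C=C/C(=O)Nc2ccc(F)c(F)c2)c1` gives 2690 nM

Both compounds were tested in a functional assay on MCF7 cells (Homo sapiens) for inhibition, read by MTT assay, with a stated time of 72 h (on this read-out lower numbers stand for stronger inhibition and higher numbers for weaker inhibition), and their numbers lie within the scatter of each other. Compound 2 at 2690 nM therefore stands level with compound 1 at 2400 nM on the numbers available, and neither can be ranked over the other.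

The next compound to be tested is compound 3 `C=C(Br)C(=O)Nc1cccc(/C=C/C(=O)Nc2ccc(OC)cc2)c1`, which keeps the core of compound 2 and differs in one place. It carries 4-methoxyphenyl in place of 3,4-difluorophenyl on an amide-type nitrogen.

Among the measured compounds shown here, no measured pair of compounds differs in a single place, so the data offer no guide to the size of such a change in this assay. With nothing to suggest a direction, the expectation starts from compound 2 at 2690 nM and foresees no shift beyond the scatter. The expected change is a 1.2-fold lower number from compound 2 to compound 3 (0.07 log units; within the scatter). Compound 3 is estimated at 2300 nM, with an expected range from 700 nM to 7500 nM.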

Compound 3, half-maximal inhibitory concentration: 2500 nM
Beside the measured number, compound 3's estimate is 1.1-fold (0.04 log units) below it; the range from low to high includes it.
By their numbers in this assay, from the lowest: compounds 1, 3 and 2 (each within the scatter of the next).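

In this assay, among the compounds shown here, the exchange of 3,4-difluorophenyl for 4-methoxyphenyl on an amide-type nitrogen gives the first comparison of compounds that differ in one place: a 1.1-fold lower number from compound 2 to compound 3 (0.03 log units; within the scatter). This position therefore tolerates one aromatic ring in place of the other, with the shared core kept, and the two compounds stand level on the numbers available. The hydrogen-bond acceptor counted on 4-methoxyphenyl and absent from 3,4-difluorophenyl makes no difference beyond the scatter in this single pair, and nothing measured here offers an explanation for that result.

This one pair cannot show whether the level result would hold for other groups on this nitrogen, such as a ring carrying an amine or a carboxylic acid, or a longer chain in place of the aromatic ring. As far as these compounds go, compound 1 differs from compound 2 and compound 3 in more than one place, so the contribution of its own groups to the read-out also remains open.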